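This account rests on a few compounds, and the source may have more. Where it says the series, first, only, none or still open, it means among the compounds named here.

Of the compounds shown here, two have so far been tested in a functional assay on PC-3 cells (Homo sapiens) for antiproliferative activity, read by ATP content, with a stated time of 48 h; on this read-out lower numbers stand for stronger inhibition and higher numbers for weaker inhibition. Compound 1 (`O=[N+]([O-])c1ccc(/C=C/c2ccc3cccc(O)c3n2)o1`) gives 140 nM, and compound 2 (`CC(=O)Oc1cc(/C=C/c2ccc([N+](=O)[O-])o2)nc2c(O)cccc12`) gives 860 nM, the higher of the two numbers. Compound 3 (`O=[N+]([O-])c1ccc(/C=C/c2cc(O)c3cccc(O)c3n2)o1`) has not yet been measured. It differs from compound 2 by a single change, hydrogen in place of acetyl on an oxygen on an aromatic ring, or acetoxy to hydroxy: hydrogen in place of acetyl on an oxygen on an aromatic ring. Going by the values given here, only one measured step bears on this change, acetoxy in place of hydrogen on an aromatic carbon, which gives a 6.1-fold higher number from compound 1 to compound 2 (0.79 log units; beyond the scatter), a modest step beyond the scatter. Among the compounds with values here, it is not an exact reverse of the new change: compound 3 keeps a hydroxy where compound 1 has hydrogen, and no measured compound carries that hydroxy. A modest move to a lower number is therefore expected, smaller than the measured step and uncertain in size. The expected change is a 2.5-fold lower number from compound 2 to compound 3 (0.39 log units; beyond the scatter). For compound 3 the estimated value is 350 nM, with an expected range from 90 nM to 1300 nM.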

Compound 3, half-maximal inhibitory concentration: 1370 nM
For compound 3 the middle estimate is 3.9-fold (0.59 log units) below the measured one; the whole stated range lies below it.
By their numbers in this assay, from the lowest: compound 1; then compounds 2 and 3 (each within the scatter of the next).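

In this assay, hydrogen in place of acetyl on the oxygen gives a 1.6-fold higher number from compound 2 to compound 3 (0.20 log units; within the scatter), so this read-out does not separate the acetoxy of compound 2 from the hydroxy of compound 3. The earlier step could have been read as a cost of the acetyl, but hydroxy in place of hydrogen on the aromatic carbon gives a 9.8-fold higher number from compound 1 to compound 3 (0.99 log units; beyond the scatter), beyond the scatter, and so the number already stands well above that of compound 1 with the acetyl gone: across these three compounds, both groups joined through oxygen at this carbon go with a higher number than hydrogen does, and no compound shown goes against this. Nothing shown offers an explanation for this result.

As far as these compounds go, whether the higher number belongs to the oxygen at this carbon or to any group placed there stays open, and a methoxy, an amine or a chlorine on the same carbon would begin to tell these apart. The three compounds also leave open whether the same order would hold on cells other than these.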